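This account rests on a few compounds, and the source may have more. Where it says the series, first, only, none or still open, it means among the compounds named here.

Measured so far in an assay on isolated protein for inhibition of acyl-CoA desaturase 1 (Rattus norvegicus); on this read-out lower numbers stand for stronger inhibition and higher numbers for weaker inhibition:
- compound 1 `CN(C)S(=O)(=O)c1ccc2nc(-c3ccc(-c4ccccc4F)cc3)[nH]c2c1`, compound 1 gives 528 nM
- compound 2 `CCS(=O)(=O)c1ccc2nc(-c3ccc(-c4ccccc4F)cc3)[nH]c2c1`, compound 2 gives 1250 nM
- compound 3 `CS(=O)(=O)c1ccc2nc(-c3ccc(-c4ccc(Cl)cc4)cc3)[nH]c2c1`, for compound 3 this assay reports only a limit, > 20000 nM

Compound 3 therefore has no number of its own; it sits at the limit of > 20000 nM in this assay, at which 1 of the 3 values shown sits, the weakest reading in this assay that can be stated. Going by the values given here, the one step measured in one place is a 2.4-fold higher number from compound 1 to compound 2 (0.37 log units; beyond the scatter), and it concerns the group on the sulfonyl sulfur, not the ring at the far end of the core. Compound 3 differs from compound 2 in two places, so nothing can be said about it beyond the limit it shows.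

Compound 4 `CS(=O)(=O)c1ccc2nc(-c3ccc(-c4cccnc4)cc3)[nH]c2c1` carries pyridin-3-yl in place of 4-chlorophenyl on an aromatic carbon. Among the compounds with values here, no measured step bears on this change, and the starting point is itself a limit. The expectation for compound 4 in this assay is thus an open one: the estimated step is an at least 2.0-fold lower number from compound 3 to compound 4 (0.30 log units; that floor lies within the scatter), toward a number that can be read, but with wide uncertainty. Compound 4 is expected to give about 10000 nM, within 2000 nM to 50000 nM, in this assay.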

Compound 4, half-maximal inhibitory concentration: 425 nM
Compound 4: middle estimate off by 24-fold (1.37 log units), on the high side, outside the stated range (below it).
By their numbers in this assay, from the lowest: compounds 4 and 1 (each within the scatter of the next); then compound 2. At a limit, above all of these: compound 3.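

Up to this point, the only step measured in one place concerned the group on the sulfonyl sulfur, so the aromatic ring at the far end of the core had no readable step of its own. In this assay, pyridin-3-yl in place of 4-chlorophenyl, on an aromatic carbon para to a large group, gives an at least 47-fold lower number from compound 3 to compound 4 (1.67 log units; beyond the scatter), which shows that the group at this position can decide whether a number can be read at all. That step is only a floor, and its true size stays unknown, because compound 3 has no number of its own, only a limit: the limit of > 20000 nM in this assay, at which 1 of the 4 values shown sits.

The change removes the chlorine and brings in a ring nitrogen at the same time, so the compounds shown do not tell which of the two carries the step, a question that a plain phenyl on the core of compound 4 would address. Also open, going by these compounds, is whether pyridin-2-yl or pyridin-4-yl would read like pyridin-3-yl, and whether pyridin-3-yl would hold its reading with dimethylamino on the sulfonyl sulfur.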